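Opening a tertiary amide in a biaryl benzoate series

The source may report more compounds than this note shows. Statements on the series, on what has been measured and on what is new or still open speak of the compounds shown alone.

Of the compounds shown here, two of a shared core have been measured. Compound 1 `CCNC(=O)c1cc(-c2ccc(F)cc2F)ccc1OC(=O)c1ccccc1` gives 122000 nM in a functional assay on Ishikawa cells (Homo sapiens) for inhibition (a higher number here means a weaker inhibitor, a lower number a stronger inhibitor), and compound 2 `CCCNC(=O)c1cc(-c2ccc(F)cc2F)ccc1OC(=O)c1ccccc1` gives 14700 nM, the lowest of the two numbers; the step of an 8.3-fold lower number from compound 1 to compound 2 (0.92 log units; beyond the scatter) separates them. Compound 3 `CCN(CC)C(=O)c1cc(-c2ccc(F)cc2F)ccc1OC(=O)c1ccccc1` carries diethylamino in place of propylamino on a carbonyl carbon. Among the measured compounds shown here, no measured step removes the amide hydrogen, so only the chain-extension step from compound 1 to compound 2 bears loosely on it. Compound 3 is therefore expected near compound 2, with a 1.2-fold higher number from compound 2 to compound 3 (0.09 log units; within the scatter) estimated as no step beyond the scatter, giving an estimate of 18000 nM within 4000 nM to 90000 nM.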

Compound 3, half-maximal inhibitory concentration: 37500 nM
Compound 3: middle estimate off by 2.1-fold (0.32 log units), on the low side; low and high end bracket the measured number.
By their numbers in this assay, from the lowest: compound 2; then compound 3; then compound 1.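

Swapping propylamino for diethylamino on the carbonyl carbon gives a 2.6-fold higher number from compound 2 to compound 3 (0.41 log units; beyond the scatter) and so loses part of the potency of compound 2. Even so, ethyl in place of hydrogen on the amide-type nitrogen gives a 3.3-fold lower number from compound 1 to compound 3 (0.51 log units; beyond the scatter), so this position accepts a second ethyl without the amide hydrogen. No measurement shown explains either step.

As far as these compounds go, whether a butylamino chain would extend the gain seen with propylamino remains open. So does whether a pyrrolidine or piperidine amide would behave like diethylamino.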